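Bromine for Fluorine on the Anilide Ring

A few compounds are considered here, and "the series" means these few. Any claim that something is new, unique, unknown or untested is made for them only; others in the source may bear on it.

Measured in an assay on isolated protein for inhibition of glutathione S-transferase Mu 2 (Homo sapiens), with a stated time of 10 min; on this read-out higher numbers stand for weaker inhibition and lower numbers for stronger inhibition:
compound 2 `O=C(CCC(=O)OCCCCCCSc1ccc([N+](=O)[O-])c2nonc12)Nc1ccc(F)cc1` gives 320 nM
compound 1 `O=C(CCC(=O)OCCCCCCSc1ccc([N+](=O)[O-])c2nonc12)Nc1cccc(Cl)c1` gives 1100 nM

Among the compounds with values here, compound 2 stands at the lowest of the two numbers, meaning the stronger inhibition; the only other compound, compound 1, sits higher by the step of a 3.4-fold lower number from compound 1 to compound 2 (0.54 log units; beyond the scatter), which swapped 4-fluorophenyl for 3-chlorophenyl on an amide-type nitrogen.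

Compound 3 `O=C(CCC(=O)OCCCCCCSc1ccc([N+](=O)[O-])c2nonc12)Nc1ccc(Br)cc1` differs from compound 2 in one place: bromo in place of fluoro on an aromatic carbon. Within the data shown here, the single measured step changed both the halogen and where it sits on the ring, so it does not speak directly to exchanging one halogen for another at the same place. Among the measured compounds shown here, with no step bearing on this exact change, the expectation is a small step, likely within the scatter or slightly weaker.

Compound 3 is therefore estimated at 400 nM, with a range from 150 nM to 1100 nM. This estimate means a step of a 1.3-fold higher number from compound 2 to compound 3 (0.10 log units; within the scatter) is expected.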

Compound 3, half-maximal inhibitory concentration: 32000 nM
Compound 3: middle estimate off by 80-fold (1.90 log units), on the low side; the measured number lies above the stated range.
By their numbers in this assay, from the lowest: compound 2; then compound 1; then compound 3.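

In this assay, within the data shown here, the earlier compounds showed only a modest difference when both the halogen and its place changed, whereas a single-atom exchange at the same place now has a far larger effect: bromo in place of fluoro gives a 100-fold higher number from compound 2 to compound 3 (2.00 log units; beyond the scatter). The 4-bromophenyl anilide also falls well behind the 3-chlorophenyl one, with a 29-fold higher number from compound 1 to compound 3 (1.46 log units; beyond the scatter), so having a halogen on this ring does not by itself preserve inhibition, and its identity or place can matter greatly. No measurement shown here explains why the bromo group costs so much.

The compounds shown leave open whether 4-chlorophenyl would fall nearer the fluoro or the bromo result. They also leave open how an unsubstituted phenyl, or a methyl, methoxy or amine group at the same place, would compare.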